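Methyl for methoxy on the aryl of compound 3

A few compounds are considered here, and "the series" means these few. Any claim that something is new, unique, unknown or untested is made for them only; others in the source may bear on it.

Compound 1 `COc1ccc(-c2ccnc(C(=O)Nc3ccc(Oc4ccnc5[nH]ccc45)cc3)n2)cc1` gives 13300 nM in a functional assay on A549 cells (Homo sapiens) for cytotoxicity, read by MTT assay, with a stated time of 72 h (a higher number here means a weaker inhibitor, a lower number a stronger inhibitor), and compound 2 `O=C(Nc1ccc(Oc2ccnc3[nH]ccc23)cc1)c1nccc(-c2ccc(Cl)cc2)n1` gives 22400 nM; the step of a 1.7-fold higher number from compound 1 to compound 2 (0.23 log units; within the scatter) stays within the scatter. Compound 3 `COc1ccc(-c2cc(C(=O)Nc3ccc(Oc4ccnc5[nH]ccc45)cc3)ncn2)cc1` gives 4410 nM, the lowest number of the three, with compound 1 nearest and compound 2 furthest, both beyond the scatter. Compound 4 `Cc1ccc(-c2cc(C(=O)Nc3ccc(Oc4ccnc5[nH]ccc45)cc3)ncn2)cc1` differs from compound 3 by methyl in place of methoxy on an aromatic carbon. Within the data shown here, the only step that bears on this is the change from compound 1 to compound 2, where the replacement of methoxy at this position did not move this assay beyond the scatter. For compound 4 the step of a 1.1-fold higher number from compound 3 to compound 4 (0.05 log units; within the scatter) is therefore expected to stay within the scatter. Compound 4 is estimated at 5000 nM, with a range of 2000 nM to 15000 nM.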

Compound 4, half-maximal inhibitory concentration: 5410 nM
Beside the measured number, compound 4's estimate is 1.1-fold (0.03 log units) below it; low and high end bracket the measured number.
By their numbers in this assay, from the lowest: compounds 3 and 4 (each within the scatter of the next); then compounds 1 and 2 (each within the scatter of the next).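

Among these compounds, the change from 4-methoxyphenyl to 4-methylphenyl gives a 1.2-fold higher number from compound 3 to compound 4 (0.09 log units; within the scatter) in this assay, the first reading of a methoxy replacement on the core of compound 3. On this core, the position therefore takes methyl in place of methoxy, with the hydrogen-bond acceptor of methoxy gone, without a step beyond the scatter. No measurement shown gives a cause for this result.

From the compounds shown here alone, whether the position also takes an amine, a carboxylic acid or a longer alkoxy chain remains open. Also open, going by these compounds, is how chloro reads on the core of compound 3.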